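Working notes: swapping the aryl group of compound 1

This account rests on a few compounds, and the source may have more. Where it says the series, first, only, none or still open, it means among the compounds named here.

In a functional assay on HeLa cells (Homo sapiens) for antiproliferative activity, read by MTT assay, with a stated time of 72 h (on this read-out lower numbers stand for stronger inhibition and higher numbers for weaker inhibition), compound 1 (`CCNC(=O)c1cc(Oc2ccc(NC(=O)c3nn(-c4ccc(Br)cc4F)c(=O)cc3C)cc2)ccn1`) is recorded as "not active" (no number reported) and so stands without a number. Two relatives give numbers: compound 2 (`CNC(=O)c1cc(Oc2ccc(NC(=O)c3nn(-c4ccccc4Cl)c(=O)cc3C)cc2F)ccn1`) reads 9870 nM and compound 3 (`CCCNC(=O)c1cc(Oc2ccc(NC(=O)c3nn(-c4ccccc4OC(F)(F)F)c(=O)cc3C)cc2F)ccn1`) reads 3690 nM in this assay under the same conditions. Among the measured compounds shown here, neither differs from compound 1 in one place only, so no single-change step is available for this series.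

Compound 4 (`CCNC(=O)c1cc(Oc2ccc(NC(=O)c3nn(-c4cccc(C(F)(F)F)c4)c(=O)cc3C)cc2)ccn1`) keeps the core of compound 1 and changes one group, with 3-(trifluoromethyl)phenyl in place of 4-bromo-2-fluorophenyl on an aromatic nitrogen is the whole difference.

With no number for compound 1, the size of this step in this assay cannot be calculated. The expected direction is a modest move towards stronger inhibition, enough at best to bring a measurable value into the range of the two relatives. That expectation rests only on compound 2 at 9870 nM and compound 3 at 3690 nM as the measured neighbours. A second result without a number remains a real possibility.

The estimate for compound 4 is 8000 nM with an expected range from 2500 nM to 25000 nM in this assay series.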

Compound 4, half-maximal inhibitory concentration: 10700 nM
The estimate for compound 4 lay 1.3-fold (0.13 log units) below the measured number; the range from low to high includes it.
By their numbers in this assay, from the lowest: compound 3; then compounds 2 and 4 (each within the scatter of the next).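

Among the compounds shown here, compound 4 gives 10700 nM in this assay, while compound 1 is recorded as "not active" (no number reported), so no step between compound 1 and compound 4 can be read. The compounds shown leave open how far 3-(trifluoromethyl)phenyl in place of 4-bromo-2-fluorophenyl shifts activity in this assay. No supporting evidence bears on this result.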